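The source may hold more compounds than are shown below. What is called first, only, known or untested is meant among the compounds shown, and "the series" means these compounds.

Measured in an ADME assay on HepG2 cells (Homo sapiens) for cytotoxicity, with a stated time of 48 h; a higher number here means a weaker inhibitor, a lower number a stronger inhibitor:
- Compound 1 `COc1ccc(Cn2c(SCc3cc([N+](=O)[O-])cc([N+](=O)[O-])c3)nnc2-c2ccccc2)cc1`: > 30000 nM, a limit of the assay
- Compound 2 `CCn1c(SCc2ccccc2)nnc1-c1cc([N+](=O)[O-])cc([N+](=O)[O-])c1`: > 30000 nM, a limit of the assay

Compound 2 therefore has no number in this assay, only a limit. The record so far consists of the limit of > 30000 nM in this assay, at which 2 of the 2 values shown sit.

Compound 3 `O=[N+]([O-])c1cc(-c2nnc(SCc3ccccc3)n2Cc2ccccc2)cc([N+](=O)[O-])c1` departs from compound 2 in one place: phenyl in place of methyl on a saturated chain carbon bound to an aromatic nitrogen. This puts phenyl in place of methyl on a saturated chain carbon bound to an aromatic nitrogen, so that ethyl becomes benzyl. For the measured compounds named here, no measured pair tests this change. The expectation rests on the limit of compound 2, > 30000 nM, and foresees no step beyond the scatter in this assay. The expected step is a number no higher from compound 2 to compound 3 (the limit leaves the size open), and another reading at the limit is likely. For compound 3 the estimated value is 30000 nM, with an expected range of 12000 nM to 60000 nM.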

Compound 3, half-maximal inhibitory concentration: > 30000 nM
Compound 3: a limit, no number (the forecaster's own chance of this, stated with the estimate: 75%); the middle value sits exactly at the limit.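

In this assay compound 3 gives > 30000 nM, a limit and not a number. For the compounds shown here, compound 2 also has only a limit, so no step from it to compound 3 can be read. On these data alone, whether phenyl in place of methyl changes cytotoxicity at all remains open.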